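A few compounds are considered here, and "the series" means these few. Any claim that something is new, unique, unknown or untested is made for them only; others in the source may bear on it.

Measured so far in a functional assay on UACC-257 cells (Homo sapiens) for cytotoxicity, read by sulforhodamine B assay, with a stated time of 48 h; a lower number here means that less compound is tolerated, a higher number that more compound is tolerated:
compound 1 `ClCc1ccc(Cn2cnc3c(Cl)ncnc32)cc1`, 97700 nM
compound 2 `ClCc1ccccc1Cn1cnc2ncnc(Cl)c21`, 61700 nM

Compound 2 holds the lower of the two numbers recorded in this assay; its nearest neighbour is compound 1, and the gap between them lies within the scatter, so neither can be called more or less tolerated than the other. Among the compounds with values here, no single-point step links compound 1 and compound 2, so only their two values can be read side by side, and both sit far from the potent end of the range.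

Compound 3 `ClCc1ccccc1Cn1cnc2nc(Cl)nc(Cl)c21` follows from compound 2 by chloro in place of hydrogen on an aromatic carbon; the chloro enters on an aromatic carbon of a six-membered aromatic ring with two nitrogen, part of a fused system of two rings, between two ring nitrogen atoms, meta to a chloro group, meta to a fused ring and para to a fused ring. Within the data shown here, no step of this kind has been measured, so its size in this assay is open. With compound 2 at 61700 nM, only a modest shift is expected, more likely toward a lower number than a higher one, and possibly nothing beyond the scatter.

For compound 3 the expected value in this assay is 45000 nM, within a range of 15000 nM to 130000 nM. This estimate implies a step of a 1.4-fold lower number from compound 2 to compound 3 (0.14 log units; within the scatter), expected to stay small.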

Compound 3, concentration lethal to 50% of the cells: 8700 nM
Compound 3: middle estimate off by 5.2-fold (0.71 log units), on the high side, outside the stated range (below it).
By their numbers in this assay, from the lowest: compound 3; then compounds 2 and 1 (each within the scatter of the next).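

In this assay, within the data shown here, chloro in place of hydrogen on an aromatic carbon, between two ring nitrogen atoms, gives the first single-place step, and it lies beyond the scatter: a 7.1-fold lower number from compound 2 to compound 3 (0.85 log units; beyond the scatter), with less compound tolerated. This position is therefore not silent: one added chloro, a single heavy atom with no hydrogen-bond donor or acceptor and no net charge, separates two compounds in this assay, something the side-by-side reading of compound 1 and compound 2 could not show. Nothing measured here accounts for the size of this step.

Among these compounds, whether the step belongs to chloro itself remains open, since the same aromatic carbon is seen only with hydrogen and chloro, and an amine, a methoxy group or a fluoro group there could give a step of a different size or direction. Also open, from the compounds shown here alone, is whether the step carries over to the framework of compound 1, and whether it holds on cells other than those of this single assay.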